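From 3-chlorophenyl to 4-chlorophenyl

This account rests on a few compounds, and the source may have more. Where it says the series, first, only, none or still open, it means among the compounds named here.

In a functional assay on U-251 cells (Homo sapiens) for antiproliferative activity, read by MTT assay, with a stated time of 48 h (on this read-out lower numbers stand for stronger inhibition and higher numbers for weaker inhibition), compound 1 `COc1cc(-c2cccc3nc(-c4cccc(Br)c4)oc23)cc(OC)c1OC` gives 6800 nM, and compound 3 `COc1cc(-c2cccc3nc(-c4cccc(Cl)c4)oc23)cc(OC)c1OC` gives 18500 nM, the higher of these two numbers. For compound 2 `COc1cc(-c2cccc3nc(-c4ccc(Br)cc4)oc23)cc(OC)c1OC`, the assay gives only a limit, > 25000 nM.

Compound 4 `COc1cc(-c2cccc3nc(-c4ccc(Cl)cc4)oc23)cc(OC)c1OC` is related to compound 3 by one change: 4-chlorophenyl in place of 3-chlorophenyl on an aromatic carbon. The closest guide is the same shift with bromo in place of chloro, an at least 3.6-fold higher number from compound 1 to compound 2 (0.56 log units; beyond the scatter). The halogen also matters, as shown by a 2.7-fold higher number from compound 1 to compound 3 (0.43 log units; beyond the scatter), so the bromo step may not carry over in full. A modest rise is therefore expected, and the expected step is a 1.7-fold higher number from compound 3 to compound 4 (0.24 log units; within the scatter). Compound 4 may return only a limit. The estimate for compound 4 is 32000 nM, with an expected range from 16000 nM to 70000 nM.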

Compound 4, half-maximal inhibitory concentration: 1600 nM
The estimate for compound 4 lay 20-fold (1.30 log units) above the measured number; the measured number lies below the stated range.
By their numbers in this assay, from the lowest: compound 4; then compound 1; then compound 3. At a limit, above all of these: compound 2.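

In this assay, 4-chlorophenyl in place of 3-chlorophenyl gives a 12-fold lower number from compound 3 to compound 4 (1.06 log units; beyond the scatter), so the drop seen with 4-bromophenyl does not apply to every halogen at this position. Compared with the bromo analogues, the result is a 4.3-fold lower number from compound 1 to compound 4 (0.63 log units; beyond the scatter) and, measured against a limit, an at least 15-fold lower number from compound 2 to compound 4 (1.19 log units; beyond the scatter). The effect of chloro in place of bromo therefore depends on where the halogen sits: the same change on two cores in this assay, a 2.7-fold higher number (0.43 log units; beyond the scatter) from compound 1 to compound 3 and an at least 15-fold lower number (1.19 log units; beyond the scatter) from compound 2 to compound 4, at least 42-fold (1.62 log units) apart, beyond the scatter of two such steps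

As far as these compounds go, whether a 4-fluorophenyl, 4-methoxyphenyl or 4-aminophenyl ring would behave like 4-chlorophenyl stays open. The compounds shown also cannot say why the two halogens differ.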